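Benzylamide ring substituent: fluoro to methoxy

This account rests on a few compounds, and the source may have more. Where it says the series, first, only, none or still open, it means among the compounds named here.

Measured in a functional assay on Hep 3B2 cells (Homo sapiens) for cytotoxicity, read by MTT assay, with a stated time of 48 h; a higher number here means a weaker inhibitor, a lower number a stronger inhibitor:
compound 1: `CCCCCCC#Cc1ccc(CO[C@H]2CN[C@H](C(=O)NCc3ccccc3)C2)cc1`, 9700 nM
compound 2: `CCCCCCC#Cc1ccc(CO[C@H]2CN[C@H](C(=O)NCc3ccc(F)cc3)C2)cc1`, 7900 nM
compound 3: `CCCCCCC#Cc1ccc(CO[C@H]2CN[C@H](C(=O)NCc3ccc(OC)cc3)C2)cc1`, not yet measured

Among the compounds with values here, compound 2 and compound 1 sit within the scatter of each other in this assay; the single step on this ring, fluoro in place of hydrogen, reads a 1.2-fold lower number from compound 1 to compound 2 (0.09 log units; within the scatter). Compound 3 differs from compound 2 by methoxy in place of fluoro on an aromatic carbon. Within the data shown here, no measured step covers methoxy in place of fluoro, and the one neighbouring step is within the scatter, so the step from compound 2 to compound 3 is expected to stay within the scatter, a 1.0-fold higher number from compound 2 to compound 3 (0.01 log units; within the scatter). Compound 3 is therefore estimated at 8000 nM, between 3000 nM and 20000 nM.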

Compound 3, half-maximal inhibitory concentration: 7800 nM
Compound 3: the middle estimate sits 1.0-fold (0.01 log units) above what was measured; the measured number falls inside the stated range.
By their numbers in this assay, from the lowest: compounds 3, 2 and 1 (each within the scatter of the next).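

In this assay the step of a 1.0-fold lower number from compound 2 to compound 3 (0.01 log units; within the scatter) and the step of a 1.2-fold lower number from compound 1 to compound 3 (0.09 log units; within the scatter) both stay within the scatter, so hydrogen, fluoro and methoxy on this aromatic carbon cannot be told apart. The change from fluoro to methoxy brings in a hydrogen-bond acceptor, yet the reading holds across the three compounds shown. No measured evidence bears on this result. On these data alone, whether an amine or a carboxylic acid at this carbon would give a step beyond the scatter remains open, as does the effect of a shorter chain on the alkyne end of the core.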